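The compounds below may be only part of what the source reports. "The series", "measured", "known", "first", "only" and "open" are said of these compounds alone.

Measured compounds in the series:

compound 1, `CCCCCCCCCC(=O)O[C@H]1[C@H](O)[C@H](n2ccc(N)nc2=O)O[C@@H]1CO`: 0.09 ug/mL
compound 2, `CCCCCCCCCCCCCC(=O)O[C@H]1[C@H](O)[C@H](n2ccc(N)nc2=O)O[C@@H]1CO`: 0.08 ug/mL
compound 3, `CCCCCCCCCCCC(=O)O[C@H]1[C@H](O)[C@H](n2ccc(N)nc2=O)O[C@@H]1CO`: 0.08 ug/mL

In a functional assay on HeLa cells (Homo sapiens) for cytotoxicity, read by cell counting, with a stated time of 48 h (on this read-out higher numbers stand for an effect only at larger amounts of compound and lower numbers for an effect already at smaller amounts), compound 3 gives 0.08 ug/mL. This puts compound 3 level with compound 2 at the digits recorded, the two together being the lowest numbers of the three, and within the scatter of compound 1.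

Compound 4, `CCCCCCCCCCCCCCCCCCCCCC(=O)O[C@H]1[C@H](O)[C@H](n2ccc(N)nc2=O)O[C@@H]1CO`, differs from compound 3 by decyl in place of hydrogen on a saturated chain carbon, ten or more bonds along the chain from a carbonyl carbon. All three measured steps bear on this change, since each alters the same chain on the same core: a 1.1-fold lower number from compound 1 to compound 2 (0.05 log units; within the scatter), a 1.1-fold lower number from compound 1 to compound 3 (0.05 log units; within the scatter) and no change at the digits printed from compound 2 to compound 3 (within the scatter). None of them left the scatter. Compound 4 extends the chain further than any measured compound, so the expectation rests on extrapolation beyond the covered span, and the range is widened accordingly. The step from compound 3 to compound 4 is expected to be a 1.5-fold higher number from compound 3 to compound 4 (0.18 log units; within the scatter). Compound 4 is therefore estimated at 0.12 ug/mL in this assay, with a range from 0.04 ug/mL to 0.5 ug/mL.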

Compound 4, concentration for half-maximal effect: 1.1 ug/mL
The estimate for compound 4 lay 9.2-fold (0.96 log units) below the measured number, and the stated range ends below it.
By their numbers in this assay, from the lowest: compounds 2, 3 and 1 (each within the scatter of the next); then compound 4.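

The chain position is not indifferent to length: in this assay decyl in place of hydrogen gives a 14-fold higher number from compound 3 to compound 4 (1.14 log units; beyond the scatter), octyl gives a 14-fold higher number from compound 2 to compound 4 (1.14 log units; beyond the scatter) and dodecyl gives a 12-fold higher number from compound 1 to compound 4 (1.09 log units; beyond the scatter), all beyond the scatter, whereas every earlier step stayed within it. The flat stretch seen so far therefore holds only for the three shorter chains and does not carry over to the chain of compound 4. Nothing available here accounts for this rise in the number.

Chains longer than in compound 2 and shorter than in compound 4 remain open, so a gradual climb cannot be told from a sharp one. Also open, going by these compounds, is whether an amine or a carboxylic acid in place of decyl would stay near the value of compound 3.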